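A few compounds are considered here, and "the series" means these few. Any claim that something is new, unique, unknown or untested is made for them only; others in the source may bear on it.

Measured in an ADME assay on S9 fraction from liver (Rattus norvegicus) for metabolic stability, read by LC-MS, using NADPH, with a stated time of 30 min; on this read-out higher numbers stand for a more stable compound and lower numbers for a less stable compound:
- compound 1 `CCCCCCCCc1ccc(OCC(=O)Cn2nnc(SC)n2)cc1`: < 5% (a limit)
- compound 2 `CCCCCCCCc1ccc(OCC(=O)Cn2nnc(C(=O)O)n2)cc1`: 52%
- compound 3 `CCCCCCCCc1ccc(OCC(=O)Cn2nnc(C(=O)OC)n2)cc1`: < 5% (a limit)

Compound 3 stands at < 5%, which is a limit of the assay and not a number. Also of note is the limit of < 5% in this assay, at which 2 of the 3 values shown sit.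

Still unmeasured is compound 4 `CCCCCCCCc1ccc(OCC(=O)Cn2nnnc2C)cc1`. It carries 5-methyl-1H-tetrazol-1-yl in place of 5-(methoxycarbonyl)-2H-tetrazol-2-yl on a saturated chain carbon bound to a carbonyl carbon.

Within the data shown here, no measured step makes this exchange. The nearest evidence is a number at least 47 percentage points higher from compound 1 to compound 2 (beyond the scatter), a large step, and a number at least 47 percentage points lower from compound 2 to compound 3 (beyond the scatter), equally large. Among the measured compounds shown here, both involve the carboxy group of compound 2, the only one of the three compounds to give a number. The remaining step, a step that the two limits leave unreadable from compound 1 to compound 3, cannot be read. Compound 4 has no carboxy group, so no step beyond the scatter is expected in this assay. The expected step is a number no lower from compound 3 to compound 4 (the limit leaves the size open).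

The estimate for compound 4 is 5%, with an expected range of 1% to 20%.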

Compound 4, percent of the compound remaining: 32%
For compound 4 the middle estimate is 27 percentage points below the measured one; the whole stated range lies below it.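

In this assay, 5-methyl-1H-tetrazol-1-yl on a saturated chain carbon bound to a carbonyl carbon gives a number at least 27 percentage points higher from compound 3 to compound 4 (beyond the scatter), and the exchange from the methylsulfanyl-bearing group gives a number at least 27 percentage points higher from compound 1 to compound 4 (beyond the scatter). A readable number at this place therefore does not require a carboxy group, although the exchange from 5-carboxy-2H-tetrazol-2-yl still gives a number 20 percentage points lower from compound 2 to compound 4 (beyond the scatter). The two steps that start from a limit stay open on one side: the limit of < 5% in this assay, at which 2 of the 4 values shown sit.

5-methyl-1H-tetrazol-1-yl differs from the 2H-tetrazol-2-yl groups in both its ring attachment and its substituent, and the compounds shown do not separate these two changes. Also open, going by these compounds, is whether 5-methyl-2H-tetrazol-2-yl, or an amine or a primary amide at the same place, would stand nearer compound 2 or compound 4.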